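The source may hold more compounds than are shown below. What is called first, only, known or untested is meant among the compounds shown, and "the series" means these compounds.

Measured so far in a functional assay on LOX IMVI cells (Homo sapiens) for inhibition (on this read-out lower numbers stand for stronger inhibition of growth and higher numbers for weaker inhibition of growth), are two compounds:
Compound 1 `C=C1CC(Cn2cc(C)c(=O)[nH]c2=O)(c2ccc(F)cc2)OC1=O` gives 4270 nM
Compound 2 `C=C1CC(Cn2ccc(=O)[nH]c2=O)(c2ccc(-c3ccccc3)cc2)OC1=O` gives 209 nM

Compound 2 stands lowest of these two numbers, and the gap up to compound 1 lies beyond the scatter. The two compounds differ in more than one place, so that gap is not a clean single step. Compound 3 `C=C1CC(Cn2ccc(=O)[nH]c2=O)(c2ccc(F)cc2)OC1=O` has yet to be measured. It follows from compound 2 through one change fluoro in place of phenyl on an aromatic carbon with fluoro in place of phenyl on an aromatic carbon, para to a large group. For the measured compounds named here, no step between measured compounds shows this exchange directly. The nearest guide is compound 1 at 4270 nM in this assay, which also carries the fluoro but differs from compound 3 elsewhere. On that basis, a large move to a higher number, beyond the scatter, is expected, meaning weaker inhibition of growth. The expected change is a 14-fold higher number from compound 2 to compound 3 (1.16 log units; beyond the scatter) as an estimate. For compound 3 the estimated value is 3000 nM, with an expected range from 1000 nM to 9000 nM in this read-out.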

Compound 3, concentration for 50% growth inhibition: 6030 nM
For compound 3 the middle estimate is 2.0-fold (0.30 log units) below the measured one, within the range that was stated.
By their numbers in this assay, from the lowest: compound 2; then compounds 1 and 3 (each within the scatter of the next).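

In this assay, the exchange of fluoro for phenyl on an aromatic carbon, para to a large group, gives a 29-fold higher number from compound 2 to compound 3 (1.46 log units; beyond the scatter) and so turns what had been a gap across two differences into a clean single step at this position. The other change, hydrogen in place of methyl on an aromatic carbon, gives a 1.4-fold higher number from compound 1 to compound 3 (0.15 log units; within the scatter) and lies within the scatter, which means that the wide gap between compound 1 and compound 2 can be read largely as the phenyl and fluoro exchange, at least with fluoro present. No independent measurement accompanies these results that could account for the large step at this position.

The compounds shown leave open whether the stronger inhibition of growth in compound 2 belongs to phenyl specifically or would also appear with another group at this place, such as chloro, methoxy, benzyl or a pyridine ring. They also leave open whether hydrogen in place of methyl on an aromatic carbon would stay within the scatter on a compound that carries phenyl rather than fluoro.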